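Second hydroxymethyl on the shared core: outlook for compound 4

A few compounds are considered here, and "the series" means these few. Any claim that something is new, unique, unknown or untested is made for them only; others in the source may bear on it.

Within the data shown here, compound 2 `Cc1cc(CO)c2n1[C@@H](c1ccccc1)SC2` gives 128000 nM in a functional assay on A-375 cells (Homo sapiens) for cytotoxicity, read by MTT assay, with a stated time of 24 h (on this read-out lower numbers stand for stronger inhibition and higher numbers for weaker inhibition), the highest of the three numbers so far. Compound 1 `Cc1c(CO)cc2n1[C@@H](c1ccccc1)SC2` gives 103000 nM, which lies within the scatter of compound 2. Compound 3 `Cc1c(COC(=O)NCc2ccccc2)cc2n1[C@@H](c1ccccc1)SC2` gives 37400 nM, a lower number than compound 2 by a gap beyond the scatter. Compound 4 `Cc1c(CO)c(CO)c2n1[C@@H](c1ccccc1)SC2` differs from compound 2 by hydroxymethyl in place of hydrogen on an aromatic carbon. Among the measured compounds shown here, no pair of measured compounds shows this change. Compound 1 and compound 2, which carry one hydroxymethyl each in different places, lie within the scatter of each other in this assay. On that ground the step of a 1.3-fold lower number from compound 2 to compound 4 (0.11 log units; within the scatter) is expected to stay within the scatter, in no clear direction. Compound 4 is therefore estimated at 100000 nM, with a range from 40000 nM to 250000 nM.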

Compound 4, half-maximal inhibitory concentration: 97300 nM
For compound 4 the middle estimate is 1.0-fold (0.01 log units) above the measured one, within the range that was stated.
By their numbers in this assay, from the lowest: compound 3; then compounds 4, 1 and 2 (each within the scatter of the next).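

Hydroxymethyl in place of hydrogen on an aromatic carbon can now be read directly in this assay: a 1.3-fold lower number from compound 2 to compound 4 (0.12 log units; within the scatter), and a 1.1-fold lower number from compound 1 to compound 4 (0.02 log units; within the scatter). Both steps lie within the scatter, so a second hydroxymethyl on the shared core brings no clear change from either compound with one hydroxymethyl. No supporting data bear on this result. On these data alone, whether an amine, a carboxylic acid or a longer chain at this aromatic carbon would give a step beyond the scatter remains open. As far as these compounds go, whether the same holds in other cell lines also remains open.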